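The compounds below may be only part of what the source reports. "The series", "measured", "known", "first", "only" and "open" are said of these compounds alone.

Going by the values given here, compound 2 `CN(C)CCCn1cnnc1-c1cc(Oc2ccc(NC(=O)Nc3ccc(Cl)c(C(F)(F)F)c3)cc2F)ccn1` is one of two compounds measured so far. In a functional assay on NCI-H460 cells (Homo sapiens) for antiproliferative activity, read by MTT assay, with a stated time of 72 h (a higher number here means a weaker inhibitor, a lower number a stronger inhibitor), compound 2 gives 1680 nM, which is the higher of the two numbers. Among the compounds with values here, the other compound, compound 1 `CCN(CC)CCn1cnnc1-c1cc(Oc2ccc(NC(=O)Nc3ccc(Cl)c(C(F)(F)F)c3)cc2F)ccn1`, gives 850 nM in this assay, and the only measured step between the two, a 2.0-fold higher number from compound 1 to compound 2 (0.30 log units; within the scatter), lies within the scatter, so the two numbers cannot be told apart with confidence.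

Compound 3 `O=C(Nc1ccc(Oc2ccnc(-c3nncn3C3CC3)c2)c(F)c1)Nc1ccc(Cl)c(C(F)(F)F)c1` is not yet measured. It differs from compound 2 in one place: cyclopropyl in place of 3-(dimethylamino)propyl on an aromatic nitrogen. Within the data shown here, the single measured step, from compound 1 to compound 2, swapped one amine-bearing chain for another amine-bearing chain and stayed within the scatter; it does not cover a change in which the whole chain leaves and a small ring enters. Among the measured compounds shown here, there is therefore no measured step that bears directly on this change, and the expectation rests on the observation that the one substitution at this ring nitrogen made no difference beyond the scatter.

Compound 3 is estimated at 2000 nM in this assay, with a range from 500 nM to 8000 nM, meaning an expected step of a 1.2-fold higher number from compound 2 to compound 3 (0.08 log units; within the scatter).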

Compound 3, half-maximal inhibitory concentration: > 50000 nM
Compound 3 was reported as a limit; the forecaster's own chance of this, stated with the estimate: 5%; middle value at least 25-fold (1.39 log units) from the limit.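

The figure for compound 3 in this assay is a limit and not a number: the limit of > 50000 nM in this assay, at which 1 of the 3 values shown sits.

This shows that the group on this aromatic nitrogen is not interchangeable. Swapping one amine-bearing chain for another gave only a 2.0-fold higher number from compound 1 to compound 2 (0.30 log units; within the scatter), whereas putting cyclopropyl in place of the chain gives an at least 29-fold higher number from compound 2 to compound 3 (1.47 log units; beyond the scatter), and measured against the other chain gives an at least 58-fold higher number from compound 1 to compound 3 (1.76 log units; beyond the scatter). Among these compounds, then, the two with an amine-bearing chain on this nitrogen give measurable numbers, while the one with a small carbon ring and no amine reaches the limit.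

The change from chain to cyclopropyl removes the amine and the open chain together, so the compounds shown cannot say which of the two losses matters, or whether the ring itself plays a part. A plain propyl chain with no amine would test the amine alone, and a cyclopropyl ring carrying a dimethylamino group would test whether the amine can restore the activity without the open chain.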